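Growth inhibition on L02 cells across an anilinopyrimidine series

This account rests on a few compounds, and the source may have more. Where it says the series, first, only, none or still open, it means among the compounds named here.

Measured compounds:
compound 1 `CCN1CCN(c2ccc(Nc3ncc(Cl)c(Nc4ccccc4C)n3)nc2)CC1`: > 100000 nM
compound 2 `Cc1ccccc1Nc1nc(Nc2ccc(N3CCN(C)CC3)cc2)ncc1Cl`: 6510 nM
compound 3 `COc1ccccc1CNc1nc(Nc2ccc(N3CCN(C)CC3)cn2)ncc1Cl`: 25500 nM

In an ADME assay on L02 cells (Homo sapiens) for inhibition, read by CCK-8 assay, with a stated time of 48 h (on this read-out lower numbers stand for stronger inhibition of growth and higher numbers for weaker inhibition of growth), compound 1 gives only a limit, > 100000 nM. Compound 2 gives 6510 nM. Compound 3 gives 25500 nM, the highest of the two numbers; compound 2 sits below it by more than the scatter.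

Compound 4 `COc1cccc(Nc2nc(Nc3ccc(N4CCN(C)CC4)cn3)ncc2Cl)c1` differs from compound 3 by 3-methoxyphenyl in place of 2-methoxybenzyl on a nitrogen on an aromatic ring. Within the data shown here, no measured pair shows this change directly; compound 1 and compound 2 carry a different group at that nitrogen. A step from compound 3 to compound 4 of modest size toward a higher number, or none beyond the scatter, is expected, a 1.6-fold higher number from compound 3 to compound 4 (0.20 log units; within the scatter). Compound 4 is therefore estimated at 40000 nM, between 12000 nM and 150000 nM.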

Compound 4, concentration for 50% growth inhibition: 3470 nM
Beside the measured number, compound 4's estimate is 12-fold (1.06 log units) above it, outside the stated range (below it).
By their numbers in this assay, from the lowest: compounds 4 and 2 (each within the scatter of the next); then compound 3. At a limit, above all of these: compound 1.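

In this assay, replacing 2-methoxybenzyl with 3-methoxyphenyl on a nitrogen on an aromatic ring gives a 7.3-fold lower number from compound 3 to compound 4 (0.87 log units; beyond the scatter). Among these compounds, this is the first single-place comparison, and it shows that the group on this nitrogen can shift the growth-inhibition number beyond the scatter. Nothing at hand bears on the cause of this step.

The change alters both the group's attachment and the methoxy position, and these two contributions remain unseparated. Also open, as far as these compounds go, is how an alkyl chain ending in an amine or carboxylic acid would read on this nitrogen.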